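Acetylation of the hydroxy group across two purine-like cores

This account rests on a few compounds, and the source may have more. Where it says the series, first, only, none or still open, it means among the compounds named here.

Measured so far:
compound 1, `OCCOCn1cnc2c(S)nc(F)nc21`: 170000 nM
compound 2, `CC(=O)OCCOCn1cnc2c(S)nc(F)nc21`: 40000 nM
compound 3, `Nc1nc(Cl)c2ncn(COCCO)c2n1`: > 200000 nM

In an ADME assay on L1210/0 cells (Mus musculus) for cytotoxicity, with a stated time of 48 h (on this read-out higher numbers stand for weaker inhibition and lower numbers for stronger inhibition), compound 1 gives 170000 nM and compound 2 gives 40000 nM. The change between them is acetyl in place of hydrogen on an oxygen on a saturated carbon. It yields a 4.3-fold lower number from compound 1 to compound 2 (0.63 log units; beyond the scatter).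

For compound 3 this assay reports only a limit, > 200000 nM. This is the limit described by the limit of > 200000 nM in this assay, at which 1 of the 3 values shown sits.

Compound 4 is `CC(=O)OCCOCn1cnc2c(Cl)nc(N)nc21` and has not yet been measured in this assay. Within the data shown here, it differs from compound 3 by acetyl in place of hydrogen on an oxygen on a saturated carbon, which is the same change as the one from compound 1 to compound 2, and the two place descriptions agree word for word. The difference between the core of compound 3 and the core of compound 1 is not broken down here.

The value of compound 4 is expected to sit at about 100000 nM, with a plausible range from 30000 nM to 300000 nM. This expectation rests on compound 3, whose result is a limit, and on the earlier step, because a 4.3-fold lower number from compound 1 to compound 2 (0.63 log units; beyond the scatter) was the effect of the same change on the core of compound 1. The step from compound 3 to compound 4 is accordingly estimated as an at least 2.0-fold lower number from compound 3 to compound 4 (0.30 log units; that floor lies within the scatter), with the note that the start of that step is a limit and not a number, so compound 4 may also be reported only as a limit.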

Compound 4, half-maximal inhibitory concentration: > 200000 nM
Compound 4 gave a limit, no number (the forecaster's own chance of this, stated with the estimate: 40%); at least 2.0-fold (0.30 log units) between middle value and limit.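

In this assay compound 4 gives > 200000 nM, which is a limit and not a number. Compound 3 also gives a limit, > 200000 nM, so no step can be read between compound 3 and compound 4: the limit of > 200000 nM in this assay, at which 2 of the 4 values shown sit.

The compounds shown leave open whether acetyl in place of hydrogen changes the number at all on the core of compound 3, and by how much.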